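This account rests on a few compounds, and the source may have more. Where it says the series, first, only, none or still open, it means among the compounds named here.

Measured so far in a functional assay on thoracic aorta (Rattus norvegicus) for inhibition; a lower number here means that less compound is needed, a higher number that more compound is needed for the effect:
compound 1 `CC1(C)CC(NC(=O)Nc2cccc(Cl)c2)c2cc(NS(C)(=O)=O)ccc2O1` gives 15200 nM
compound 2 `CCS(=O)(=O)Nc1ccc2c(c1)C(NC(=O)Nc1cccc(C#N)c1)CC(C)(C)O2` gives 9500 nM
compound 3 `CCS(=O)(=O)Nc1ccc2c(c1)C(NC(=O)Nc1ccc(C#N)cc1)CC(C)(C)O2` gives 11800 nM

Compound 3 stands second highest of the three numbers; its nearest neighbour is compound 2 and its furthest is compound 1, and both gaps lie within the scatter, so the three compounds are not separated in this assay.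

Compound 4 `CCS(=O)(=O)Nc1ccc2c(c1)C(NC(=O)Nc1cccc(Cl)c1)CC(C)(C)O2` is not yet measured. It differs from compound 3 by 3-chlorophenyl in place of 4-cyanophenyl on an amide-type nitrogen.

Among the measured compounds shown here, the only measured step on this core moves the nitrile around the ring: a 1.2-fold higher number from compound 2 to compound 3 (0.09 log units; within the scatter), within the scatter. For the measured compounds named here, no measured step exchanges a nitrile for a chlorine on the same core. Compound 1 also carries 3-chlorophenyl on the amide-type nitrogen, but it differs from compound 4 in a second place as well, so its value is a pointer only. On this basis the exchange is expected to produce no step beyond the scatter, a 1.1-fold higher number from compound 3 to compound 4 (0.04 log units; within the scatter).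

Compound 4 is therefore estimated at 13000 nM, with a range from 6000 nM to 30000 nM.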

Compound 4, half-maximal effective concentration: 17200 nM
Estimate against measurement, compound 4: 1.3-fold (0.12 log units) below; measured number inside the range.
By their numbers in this assay, from the lowest: compounds 2, 3, 1 and 4 (each within the scatter of the next).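

In this assay, chloro in place of cyano on the aromatic carbon gives a 1.8-fold higher number from compound 2 to compound 4 (0.26 log units; within the scatter), and moving to 3-chlorophenyl from 4-cyanophenyl on the amide-type nitrogen gives a 1.5-fold higher number from compound 3 to compound 4 (0.16 log units; within the scatter), so neither the exchange of these two groups nor the combined change of group and ring place separates the compounds on this core. The first single-place step away from the aryl group, methyl in place of hydrogen on the saturated chain carbon bound to the sulfonyl sulfur, gives a 1.1-fold higher number from compound 1 to compound 4 (0.05 log units; within the scatter) and leaves that compound pair unseparated as well. No measurement is at hand that could explain these results.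

All the steps so far lie within the scatter, so no group shown here is yet known to move the number in this assay. On these data alone, whether an amine or a carboxylic acid on the aryl ring, or a longer chain on the sulfonyl sulfur, would produce a step beyond the scatter remains open.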